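The compounds below may be only part of what the source reports. "The series", "measured", "known", "first", "only" and "open" are said of these compounds alone.

Compound 1 `CCOC(=O)C1=Cc2ccccc2OC1(OCc1cc(-c2ccc(OC)cc2)no1)C(F)(F)F` is the starting point. In a functional assay on HeLa cells (Homo sapiens) for inhibition, read by MTT assay, with a stated time of 24 h (on this read-out lower numbers stand for stronger inhibition and higher numbers for weaker inhibition), compound 1 gives only a limit, > 150000 nM, and no number; it sits at the limit of > 150000 nM in this assay, at which 1 of the 2 values shown sits. Compound 2 `CCOC(=O)C1=Cc2ccccc2OC1(OCc1cn(-c2ccc(F)c(Cl)c2)nn1)C(F)(F)F` differs from compound 1 in several places. In this assay, among the measured compounds shown here, compound 2 gives 22700 nM, so it is the one compound here with a measured value. Compound 3 `CCOC(=O)C1=Cc2ccccc2OC1(OCc1cc(-c2cccc(C(F)(F)F)c2)no1)C(F)(F)F` is not yet measured; it differs from compound 1 by 3-(trifluoromethyl)phenyl in place of 4-methoxyphenyl on an aromatic carbon. For the measured compounds named here, no measured step in this assay matches that change, and with compound 1 held at a limit, the step cannot be sized from the data. Compound 3 is estimated at 60000 nM, within 15000 nM to 200000 nM, with a real chance that this assay again returns only a limit; the expected step of an at least 2.5-fold lower number from compound 1 to compound 3 (0.39 log units; beyond the scatter) would be toward stronger inhibition, but only modestly so.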

Compound 3, half-maximal inhibitory concentration: 21400 nM
Beside the measured number, compound 3's estimate is 2.8-fold (0.45 log units) above it; the measured number falls inside the stated range.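

In this assay, the aromatic carbon of the five-membered ring, next to the ring nitrogen, proves sensitive to the group it carries: 3-(trifluoromethyl)phenyl in place of 4-methoxyphenyl gives an at least 7.0-fold lower number from compound 1 to compound 3 (0.84 log units; beyond the scatter). With this change, compound 3 gives 21400 nM, so this ring series now has a measured number where compound 1 offered none. The step still has only a lower bound, and compound 1 stands at a limit: the limit of > 150000 nM in this assay, at which 1 of the 3 values shown sits.

On these data alone, what a plain phenyl or a 3-methoxyphenyl would give at this carbon stays open, so the change of substituent cannot be separated from the change of its place on the phenyl ring. Also open, as far as these compounds go, is how an amine or a carboxylic acid on that phenyl ring would read in this assay.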